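A Larger Group Added to a Core Without Measured Potency

The source may report more compounds than this note shows. Statements on the series, on what has been measured and on what is new or still open speak of the compounds shown alone.

Three compounds have been measured in an assay on U-937 cells for inhibition of Fatty-acid amide hydrolase 1 (Homo sapiens), read by scintillation counting, with a stated time of 15 min; on this read-out lower numbers stand for stronger inhibition and higher numbers for weaker inhibition:
Compound 1 `Cc1ccc(C(=O)NC2CCCCCC2)c(=O)n1Cc1ccc(F)cc1` gives > 10000 nM, a limit of the assay.
Compound 2 `CC(=O)N[C@@H]1[C@@H](O)[C@H](O)[C@@H](CO)O[C@H]1NC(=O)c1cc(Br)c(C)n(Cc2ccc(F)cc2)c1=O` gives > 10000 nM, also a limit.
Compound 3 `Cc1ccc(C(=O)NC2CCCCCC2)c(OCc2ccc(F)cc2)n1` gives > 10000 nM, again a limit.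

Among the compounds with values here, compound 3 therefore stands where all three measured compounds stand, at the limit of > 10000 nM in this assay, at which 3 of the 3 values shown sit; no number below the limit exists for any of them, and no step between measured compounds can be drawn. Compound 4 `COc1ccc(-c2cc(C(=O)NC3CCCCCC3)c(OCc3ccc(F)cc3)nc2C)cc1` differs from compound 3 by 4-methoxyphenyl in place of hydrogen on an aromatic carbon. Within the data shown here, with no measured step to lean on, only a weak expectation is possible: a gain of an at least 1.6-fold lower number from compound 3 to compound 4 (0.22 log units; that floor lies within the scatter) is expected, though the chance that this assay again reports only a limit remains large. For compound 4 the estimate is 6000 nM, with a range from 800 nM to 30000 nM.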

Compound 4, half-maximal inhibitory concentration: > 10000 nM
Compound 4 gave a limit, no number (the forecaster's own chance of this, stated with the estimate: 55%); at least 1.6-fold (0.22 log units) between middle value and limit.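

Within the data shown here, compound 3 and compound 4 both return only a limit of the assay, so no step between them can be read. Whether 4-methoxyphenyl in place of hydrogen changes inhibition at all, and how strongly any of these compounds inhibits, stays open.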